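Swapping (pyridin-4-yl)carbonyl for benzyl on the shared core

The source may report more compounds than this note shows. Statements on the series, on what has been measured and on what is new or still open speak of the compounds shown alone.

In a functional assay on MKN-45 cells (Homo sapiens) for cytotoxicity (a higher number here means a weaker inhibitor, a lower number a stronger inhibitor), compound 1 `COc1ccc(S(=O)(=O)N2CCc3cccc(NC(=O)c4ccc(F)cc4)c32)cc1` gives 45 nM, while compound 2 `COc1ccc(S(=O)(=O)N2CCc3cccc(NC(=O)c4ccncc4)c32)cc1` gives 8.8 nM, the lower of the two numbers and so the stronger inhibitor. Within the data shown here, the one measured step, a 5.1-fold lower number from compound 1 to compound 2 (0.71 log units; beyond the scatter), came from pyridin-4-yl in place of 4-fluorophenyl on a carbonyl carbon. Compound 3 `COc1ccc(S(=O)(=O)N2CCc3cccc(NCc4ccccc4)c32)cc1` carries benzyl in place of (pyridin-4-yl)carbonyl on a nitrogen on an aromatic ring. Both measured compounds keep the carbonyl, so no measurement shows what losing it does, and the earlier step is only a loose guide. It suggests that swapping this group can shift this assay beyond the scatter, and a shift of similar or greater size toward a higher number seems likely. The expected change is a 5.7-fold higher number from compound 2 to compound 3 (0.75 log units; beyond the scatter). For compound 3 the estimated value is 50 nM, with an expected range of 9 nM to 300 nM.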

Compound 3, half-maximal inhibitory concentration: > 10000 nM
Compound 3: no number, only a limit (the forecaster's own chance of this, stated with the estimate: 4%); middle value at least 200-fold (2.30 log units) away from the limit.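

Replacing the carbonyl-linked ring on this nitrogen with benzyl has a much larger effect than exchanging one ring for another on the carbonyl, which gave only a 5.1-fold lower number from compound 1 to compound 2 (0.71 log units; beyond the scatter). Here the changes give an at least 1100-fold higher number from compound 2 to compound 3 (3.05 log units; beyond the scatter) and an at least 220-fold higher number from compound 1 to compound 3 (2.34 log units; beyond the scatter), both large. In this assay compound 3 stands at a limit of the assay and not at a number, so these sizes are lower bounds: the limit of > 10000 nM in this assay, at which 1 of the 3 values shown sits.

The two carbonyl compounds carry different rings and both give measurable values, but benzyl changes the ring and removes the carbonyl in one step, so the two effects cannot be separated here. Going by these compounds, a (pyridin-4-yl)methyl group on this nitrogen would keep the pyridine ring without the carbonyl, and a sulfonyl link would replace the carbonyl with another linker, so how either would read remains open.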